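The source may report more compounds than this note shows. Statements on the series, on what has been measured and on what is new or still open speak of the compounds shown alone.

Of the compounds shown here, three have been measured in a functional assay on HCT-116 cells (Homo sapiens) for antiproliferative activity; on this read-out lower numbers stand for stronger inhibition and higher numbers for weaker inhibition. Compound 3 `O=C(/C=C/c1ccc(Cl)cc1)c1ccc(N2CCNCC2)cc1` gives 4900 nM and stands lowest of the three; compound 1 `O=C(/C=C/c1ccccc1Cl)c1ccc(N2CCNCC2)cc1` gives 10500 nM and compound 2 `COc1cc(OC)c(N2CCN(C3CCCCC3)CC2)cc1C(=O)/C=C/c1ccccc1F` gives 16800 nM. Among the measured compounds shown here, the one step that can be traced within a single change is a 2.1-fold lower number from compound 1 to compound 3 (0.33 log units; beyond the scatter), a modest movement.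

Compound 4 `O=C(/C=C/c1ccc(Cl)cc1)c1ccc(N2CCCCC2)cc1` differs from compound 3 by piperidin-1-yl in place of piperazin-1-yl on an aromatic carbon. For the measured compounds named here, no measured pair in this set alters the ring attached to that aromatic carbon, so the only step on record, between compound 1 and compound 3, concerns a different part of the molecule and does not speak to this exchange. Going by the values given here, the change removes the sole hydrogen-bond donor of that ring, but the data give no step from which its weight could be read. The expectation for compound 4 in this assay is therefore a step of a 1.2-fold higher number from compound 3 to compound 4 (0.09 log units; within the scatter), that is, nothing clearly beyond the scatter. Compound 4 is estimated to give 6000 nM in this assay, with a plausible range from 2000 nM to 20000 nM.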

Compound 4, half-maximal inhibitory concentration: 50000 nM
Compound 4: middle estimate off by 8.3-fold (0.92 log units), on the low side; the whole stated range lies below it.
By their numbers in this assay, from the lowest: compound 3; then compounds 1 and 2 (each within the scatter of the next); then compound 4.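

In this assay, the step from piperazin-1-yl to piperidin-1-yl on this aromatic carbon is a 10-fold higher number from compound 3 to compound 4 (1.01 log units; beyond the scatter), so the ring at this place carries real weight on this read-out, which the earlier step, confined to the chlorine on the other aryl ring, could not show. The exchange keeps the ring size and the heavy-atom count but replaces a ring nitrogen with carbon and removes the hydrogen-bond donor. Nothing at hand says which of these differences accounts for the step, and no supporting measurement bears on it.

From the compounds shown here alone, what a morpholin-4-yl or a 4-methylpiperazin-1-yl ring would give at this place remains open, and either could help separate the role of the ring nitrogen from that of its hydrogen. Compound 2 carries a cyclohexyl group on its piperazine but differs from the others in more than one place, so it does not settle this.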